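Chloro for diethylamino in a series at its limit

The source may hold more compounds than are shown below. What is called first, only, known or untested is meant among the compounds shown, and "the series" means these compounds.

In a functional assay on HeLa cells (Homo sapiens) for cytotoxicity, read by CCK-8 assay (a higher number here means a weaker inhibitor, a lower number a stronger inhibitor), compound 1 `Cc1ccc(NC(=O)c2ncc(-c3ccccc3)o2)cc1` gives > 30000 nM, which is a limit. Compound 2 `CN(C)c1ccc(NC(=O)c2ncc(-c3ccccc3)o2)cc1` gives > 30000 nM, also a limit. Compound 3 `CCN(CC)c1ccc(NC(=O)c2ncc(-c3ccccc3)o2)cc1` gives > 30000 nM, again a limit and not a number. For the measured compounds named here, the series so far offers only (the limit of > 30000 nM in this assay, at which 3 of the 3 values shown sit).

Compound 4 `O=C(Nc1ccc(Cl)cc1)c1ncc(-c2ccccc2)o1` carries chloro in place of diethylamino on an aromatic carbon. Going by the values given here, the steps that bear on it are a step that the two limits leave unreadable from compound 1 to compound 2, a step that the two limits leave unreadable from compound 1 to compound 3 and a step that the two limits leave unreadable from compound 2 to compound 3. Among the compounds with values here, with these as the only measured steps, no size can be carried over, and no shift in either direction is expected for compound 4. The estimated step is a number no higher from compound 3 to compound 4 (the limit leaves the size open). For compound 4 the expected value is 30000 nM, within an estimated range of 10000 nM to 60000 nM.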

Compound 4, half-maximal inhibitory concentration: > 30000 nM
Compound 4: a limit, no number; the forecaster's own chance of this, stated with the estimate: 70%; the middle value sits exactly at the limit.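

In this assay compound 4 gives > 30000 nM as a limit and not a number. For the compounds shown here, no step from compound 1, compound 2 or compound 3 to compound 4 can be read, because all four sit at one limit: (the limit of > 30000 nM in this assay, at which 4 of the 4 values shown sit). The compounds shown leave open what actual value any of the four has in this assay and whether the group on the aromatic carbon matters there.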